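From Compound 1 to Compound 4: a Cytotoxicity Forecast

This account rests on a few compounds, and the source may have more. Where it says the series, first, only, none or still open, it means among the compounds named here.

Compound 1 `CC(C)Cn1cc(-c2cc(Nc3ccc(OC(F)(F)F)cc3)ncn2)cn1` was tested in an ADME assay on BaF3 cells (Mus musculus) for cytotoxicity; on this read-out higher numbers stand for an effect only at larger amounts of compound and lower numbers for an effect already at smaller amounts. Compound 1 gives > 10000 nM, which is a limit of this assay rather than a number. Two further compounds were tested alongside it. Compound 2 `O=C(c1cc2c(Nc3ccc(OC(F)(F)F)cc3)ncnc2s1)N1CCC(O)CC1` gives > 10000 nM, again a limit. Compound 3 `FC(F)(F)Oc1ccc(Nc2ncnc3nn(Cc4ccccc4)cc23)cc1` gives > 10000 nM, also a limit. Among the measured compounds shown here, compound 1 thus stands at the limit of > 10000 nM in this assay, at which 3 of the 3 values shown sit, with no measured step that would set it apart from the others. Compound 4 `NC(=O)c1ccccc1-c1cc(Nc2ccc(OC(F)(F)F)cc2)ncn1` differs from compound 1 in one place: 2-carbamoylphenyl in place of 1-isobutyl-1H-pyrazol-4-yl on an aromatic carbon. For the measured compounds named here, no measured step covers such a change, so the expected step is a step that the limit leaves unreadable from compound 1 to compound 4, none beyond the usual scatter. Compound 4 is therefore estimated at 15000 nM, between 5000 nM and 50000 nM, most likely reported again only as a limit.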

Compound 4, half-maximal effective concentration: > 10000 nM
Compound 4: only a limit was reported; the forecaster's own chance of this, stated with the estimate: 85%; the middle value does not contradict the limit.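

Among the compounds shown here, compound 1 and compound 4 are both reported only as limits, so no step between them can be read: the limit of > 10000 nM in this assay, at which 4 of the 4 values shown sit. The compounds shown leave open at what concentration any of them affects these cells, and whether 2-carbamoylphenyl in place of 1-isobutyl-1H-pyrazol-4-yl changes that concentration.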